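Chain-amine variation in the aryloxyalkylamine chromenone series

The source may report more compounds than this note shows. Statements on the series, on what has been measured and on what is new or still open speak of the compounds shown alone.

Measured so far:
compound 1 `CN(C)CCCCCCCCOc1ccc2oc(-c3ccccc3)cc(=O)c2c1`, an assay on isolated protein (Cavia porcellus) with Sigma non-opioid intracellular receptor 1 (Homo sapiens) as the target, read by radioligand binding (a lower number here means a stronger inhibitor, a higher number a weaker inhibitor), 227 nM
compound 2 `CN(C)CCCCCCCCCCOc1ccc2oc(-c3ccccc3)cc(=O)c2c1`, this assay 297 nM
compound 3 `O=c1cc(-c2ccccc2)oc2ccc(OCCCCCCN3CCCC(O)C3)cc12`, this assay 86 nM

Compound 3 gives the lowest number of the three, with a 2.6-fold lower number from compound 1 to compound 3 (0.42 log units; beyond the scatter) and a 3.5-fold lower number from compound 2 to compound 3 (0.54 log units; beyond the scatter), while a 1.3-fold higher number from compound 1 to compound 2 (0.12 log units; within the scatter). Compound 4 `CCN(CC)CCCCCCOc1ccc2oc(-c3ccccc3)cc(=O)c2c1` is not yet measured; relative to compound 3 the change is diethylamino in place of 3-hydroxypiperidin-1-yl on a saturated chain carbon, six bonds along the chain from an oxygen on an aromatic ring. Among the compounds with values here, no measured pair isolates this exact exchange. The two steps that bear on it run the other way: both replacements of an open-chain dimethylamino by the 3-hydroxypiperidin-1-yl lowered the number modestly. Reversing that, with diethylamino entering on the six-carbon chain, a modest rise toward the numbers of compound 1 and compound 2 is expected, a 2.1-fold higher number from compound 3 to compound 4 (0.32 log units; beyond the scatter). Compound 4 is therefore estimated at 180 nM, range 70 nM to 450 nM.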

Compound 4, half-maximal inhibitory concentration: 91 nM
The estimate for compound 4 lay 2.0-fold (0.30 log units) above the measured number, within the range that was stated.
By their numbers in this assay, from the lowest: compounds 3 and 4 (each within the scatter of the next); then compounds 1 and 2 (each within the scatter of the next).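

At this place, on a saturated chain carbon six bonds along the chain from an oxygen on an aromatic ring, the ring and hydroxyl of 3-hydroxypiperidin-1-yl prove dispensable, with a 1.1-fold higher number from compound 3 to compound 4 (0.02 log units; within the scatter) and no order between the two. An open-chain amine also sits clear of the longer-chain compounds, with a 3.3-fold lower number from compound 2 to compound 4 (0.51 log units; beyond the scatter) and a 2.5-fold lower number from compound 1 to compound 4 (0.40 log units; beyond the scatter), though amine and chain length change together in those pairs. No evidence on the cause of these results is at hand.

The compounds shown leave open how dimethylamino on this shorter chain would compare, which would separate amine from chain length. They also leave open how a morpholin-4-yl group would fare here.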